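Second chloro on the core of a benzylpurine pair

The compounds below may be only part of what the source reports. "The series", "measured", "known", "first", "only" and "open" are said of these compounds alone.

Two compounds carry numbers in a functional assay on HCC 2998 cells (Homo sapiens) for cytotoxicity, read by sulforhodamine B assay, with a stated time of 48 h; on this read-out lower numbers stand for stronger inhibition of growth and higher numbers for weaker inhibition of growth. Compound 1 `ClCc1cccc(Cn2cnc3ncnc(Cl)c32)c1` gives 3230 nM, the lowest of the two. Compound 2 `ClCc1ccc(Cn2cnc3c(Cl)nc(Cl)nc32)cc1` gives 24000 nM, a higher number; the two structures differ in more than one place, so the gap between them cannot be tied to one change. Compound 3 `ClCc1cccc(Cn2cnc3nc(Cl)nc(Cl)c32)c1` is not yet measured in this assay. It differs from compound 1 by chloro in place of hydrogen on an aromatic carbon. For the measured compounds named here, no single-change step is known here; the expected step is a 2.2-fold higher number from compound 1 to compound 3 (0.34 log units; beyond the scatter), toward weaker inhibition, beyond the scatter. Compound 3 is expected to give about 7000 nM, within 2500 nM to 20000 nM.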

Compound 3, concentration for total growth inhibition: 3310 nM
Compound 3: middle estimate off by 2.1-fold (0.33 log units), on the high side, within the range that was stated.
By their numbers in this assay, from the lowest: compounds 1 and 3 (each within the scatter of the next); then compound 2.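

In this assay, for the compounds shown here, chloro in place of hydrogen on the aromatic carbon between two ring nitrogen atoms gives a 1.0-fold higher number from compound 1 to compound 3 (0.01 log units; within the scatter) and so provides the first single-change step. This position therefore accepts chloro with no shift in the growth-inhibition read-out beyond the scatter. Nothing available gives a reason for this result.

As far as these compounds go, whether an amine or a methoxy group on the same carbon would also leave the number within the scatter remains open. So does the effect of replacing the chloromethyl group with a hydroxymethyl group.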